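The compounds below may be only part of what the source reports. "The series", "measured", "known", "first", "only" and "open" are said of these compounds alone.

Series notes. Compound 1, `O=C1CNc2nc(Nc3ccccc3)ncc2N1`, is the unsubstituted parent of the shared core. In a functional assay on MDA-MB-231 cells (Homo sapiens) for cytotoxicity, read by MTT assay, with a stated time of 48 h (a higher number here means a weaker inhibitor, a lower number a stronger inhibitor), compound 1 gives only a limit, > 100000 nM. Compound 2, `O=C1CNc2nc(Nc3ccc(Cl)cc3)ncc2N1`, adds a chloro to the aromatic ring, and in this assay compound 2 gives 41700 nM. Among the measured compounds shown here, the step of an at least 2.3-fold lower number from compound 1 to compound 2 (0.37 log units; beyond the scatter) is the single measured step in the set, and its true size is bounded below by the limit of > 100000 nM in this assay, at which 1 of the 2 values shown sits, rather than known. For the measured compounds named here, compound 2 therefore holds the only real number in this assay; the other value is a limit.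

Compound 3, `COc1ccc(Nc2ncc3c(n2)NCC(=O)N3)cc1`, differs from compound 2 by methoxy in place of chloro on an aromatic carbon. Going by the values given here, no measured step exchanges chloro for methoxy, so the step from compound 1 to compound 2 bears only indirectly: it shows that a substituent at this place brings the number down from the limit. Whether methoxy holds that gain is open, and a modest drift back toward weaker inhibition is the expected outcome, given as the step of a 1.7-fold higher number from compound 2 to compound 3 (0.22 log units; within the scatter). Compound 3 is accordingly expected to give 70000 nM in this assay, with a range of 30000 nM to 160000 nM.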

Compound 3, half-maximal inhibitory concentration: > 100000 nM
Compound 3: no number, only a limit; the forecaster's own chance of this, stated with the estimate: 35%; middle value at least 1.4-fold (0.15 log units) away from the limit.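

The step of an at least 2.3-fold higher number from compound 2 to compound 3 (0.37 log units; beyond the scatter) shows, in this assay, that the gain seen with chloro does not carry over to methoxy at this place, on an aromatic carbon para to a large group. A substituent on this carbon is therefore not enough in itself: of the two groups shown here, only chloro brings the number within the range of the assay, so the outcome depends on which group enters and not merely on hydrogen being replaced. Compound 3 gives only a limit, so the step from compound 1 to compound 3 cannot be read and methoxy and hydrogen cannot be ordered at this place: the limit of > 100000 nM in this assay, at which 2 of the 3 values shown sit.

As far as these compounds go, how far the true value of compound 3 lies past its limit stays open, and with it the full size of the difference between chloro and methoxy. Also open, from the compounds shown here alone, is whether bromo, trifluoromethyl or an amine at this same place would give a real number at all, and whether any of them would improve on compound 2 at 41700 nM in this assay.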